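The source may hold more compounds than are shown below. What is called first, only, known or untested is meant among the compounds shown, and "the series" means these compounds.

Compound 1 `Cc1ccc(S(=O)(=O)N2N=C(c3ccc(N4CCN(C)CC4)cc3)CC2c2ccc(N(C)C)cc2)cc1` — 38.1%
Compound 2 `CN1CCN(c2ccc(C3=NN(S(=O)(=O)c4ccc(C#N)cc4)C(c4ccc(N(C)C)cc4)C3)cc2)CC1` — 100%
Compound 3 `Cc1ccc(S(=O)(=O)N2N=C(c3ccc(-n4ccnc4)cc3)CC2c2ccc(N(C)C)cc2)cc1` — 50.5%

Of the compounds shown here, three built on a shared core have been tested in a functional assay on NCI-H1975 cells (Homo sapiens) for inhibition, read by sulforhodamine B assay, tested at 10 uM; on this read-out higher numbers stand for more inhibition at the one concentration tested (going by the name of the read-out) and lower numbers for less inhibition. Compound 1 and compound 2 differ in one place: cyano in place of methyl on an aromatic carbon. This change produces a number 61.9 percentage points higher from compound 1 to compound 2 (beyond the scatter), carrying the read-out to the highest number of the three at the single concentration tested. Compound 3 differs from compound 1 in its core: 1H-imidazol-1-yl in place of 4-methylpiperazin-1-yl on an aromatic carbon. That change produces a number 12.4 percentage points higher from compound 1 to compound 3 (beyond the scatter), so compound 3 stands second of the three numbers, beyond the scatter above compound 1 and well beneath compound 2.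

Compound 4 `CN(C)c1ccc(C2CC(c3ccc(-n4ccnc4)cc3)=NN2S(=O)(=O)c2ccc(C#N)cc2)cc1` has not been measured in this assay. It differs from compound 3 in one place: cyano in place of methyl on an aromatic carbon. This is the same change that separates compound 1 from compound 2, and it sits at the same place, so the two occurrences are the same change on two different cores. Compound 3 starts from 50.5%, a higher point than compound 1, and the read-out cannot rise past the top of the percentage scale. The step from compound 3 to compound 4 is therefore expected to be a number 44.5 percentage points higher from compound 3 to compound 4 (beyond the scatter), somewhat smaller than the earlier one because a number 61.9 percentage points higher from compound 1 to compound 2 (beyond the scatter) already reached the top of the scale from a lower start. Compound 4 is expected to give 95%, most likely between 78% and 100%.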

Compound 4, a percentage reported as inhibition, at one concentration (the size of the read-out at that concentration, not a potency): 0.7%
Beside the measured number, compound 4's estimate is 94.3 percentage points above it; measured number below the stated range.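

In this assay, the change from 4-methylphenyl to 4-cyanophenyl on the sulfonyl group did not carry over from one core to the other, giving a number 49.8 percentage points lower from compound 3 to compound 4 (beyond the scatter), opposite in direction to its effect on the core of compound 1: the same change on two cores in this assay, a number 61.9 percentage points higher (beyond the scatter) from compound 1 to compound 2 and a number 49.8 percentage points lower (beyond the scatter) from compound 3 to compound 4, 111.7 percentage points apart, beyond the scatter of two such steps. The exchange of 4-methylpiperazin-1-yl for 1H-imidazol-1-yl likewise changed with its setting, giving a number 99.3 percentage points lower from compound 2 to compound 4 (beyond the scatter), whereas the same exchange raised the number when the methyl group was present: the same change on two cores in this assay, a number 12.4 percentage points higher (beyond the scatter) from compound 1 to compound 3 and a number 99.3 percentage points lower (beyond the scatter) from compound 2 to compound 4, 111.7 percentage points apart, beyond the scatter of two such steps. Within these four compounds, the effect of each change therefore depends on the group present at the other place, but the result rests on a single square of compounds at one concentration in one cell line, and it neither explains the reversal nor establishes a rule for the wider series.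

The compounds shown leave open whether a chloro, trifluoromethyl or methoxy group in place of the cyano group would follow compound 2 or compound 4 on these two cores. They also leave open whether a morpholine or a pyrazole in place of the 1H-imidazol-1-yl group would restore the high number seen with the cyano group on the core of compound 2.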